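A few compounds are considered here, and "the series" means these few. Any claim that something is new, unique, unknown or untested is made for them only; others in the source may bear on it.

Compound 3 `Nc1ccccc1NC(=O)c1ccc(CSC(=S)N2CCCC2)cc1` gives 77.8% in a functional assay on HeLa cells (Homo sapiens) for antiproliferative activity, read by CCK-8 assay, with a stated time of 72 h, tested at 8 uM (on this read-out lower numbers stand for a weaker effect and higher numbers for a stronger effect at the one concentration tested), the highest of the three numbers shown, although compound 1 `Nc1ccccc1NC(=O)c1ccc(CSC(=S)N2CCN(c3ccncc3)CC2)cc1`, with 77.4%, sits within the scatter of it, and only compound 2 `Nc1ccccc1NC(=O)c1ccc(CSC(=S)N2CCN(Cc3ccccc3)CC2)cc1`, with 31.3%, lies beyond it. Compound 4 `CN1CCN(C(=S)SCc2ccc(C(=O)Nc3ccccc3N)cc2)CC1` differs from compound 3 in one place: 4-methylpiperazin-1-yl in place of pyrrolidin-1-yl on a thiocarbonyl carbon. Among the compounds with values here, no measured step changes the group on the thiocarbonyl carbon itself. The only step shown, a number 46.1 percentage points lower from compound 1 to compound 2 (beyond the scatter), concerns the substituent on a piperazine nitrogen and shows that such a change can be large. Since compounds 1 and 3 lie together, the estimate for compound 4 is placed somewhat lower, with wide uncertainty, at 60%, between 30% and 85%, an expected step of a number 17.8 percentage points lower from compound 3 to compound 4 (beyond the scatter).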

Compound 4, a percentage reported as inhibition, at one concentration (the size of the read-out at that concentration, not a potency): 75.7%
Estimate against measurement, compound 4: 15.7 percentage points below; the measured number falls inside the stated range.
By their numbers in this assay, from the lowest: compound 2; then compounds 4, 1 and 3 (each within the scatter of the next).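

In this assay, the change on the thiocarbonyl carbon leaves the read-out unmoved (a number 2.1 percentage points lower from compound 3 to compound 4 (within the scatter)), so pyrrolidin-1-yl and 4-methylpiperazin-1-yl cannot be told apart at this position. On the piperazine nitrogen, methyl and pyridin-4-yl also cannot be told apart (a number 1.7 percentage points lower from compound 1 to compound 4 (within the scatter)), while benzyl stands alone among these compounds (a number 44.4 percentage points higher from compound 2 to compound 4 (beyond the scatter)). No measurement shown accounts for these numbers. Still open, on these data alone, is whether an open-chain diethylamino group or a morpholine ring on the thiocarbonyl carbon would fit this picture. Also open, as far as these compounds go, is whether a phenyl or a longer alkyl chain on the piperazine nitrogen would follow methyl or benzyl.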